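Ring Size Change on the Amine Side Chain

The source may hold more compounds than are shown below. What is called first, only, known or untested is meant among the compounds shown, and "the series" means these compounds.

Compound 2 `COc1cc2nnc(C(N)=O)c(Nc3ccc(C)cc3F)c2cc1N1CCN(C(C)C)CC1` carries a 4-isopropylpiperazin-1-yl group on the shared core. In an ADME assay on a cell-free system (plasma, Rattus norvegicus) for protein binding (a lower number here means a smaller unbound share, a higher number a larger unbound share of the compound), compound 2 gives 0.066. Compound 1 `COc1cc2nnc(C(N)=O)c(Nc3ccc(C)cc3F)c2cc1N1CCN(C)CC1` differs only in the group on the amine nitrogen in the ring, and in this assay compound 1 gives 0.063; the two values lie within the scatter of each other, as the step of a 1.0-fold higher number from compound 1 to compound 2 (0.02 log units; within the scatter) shows.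

Compound 3 `COc1cc2nnc(C(N)=O)c(Nc3ccc(C)cc3F)c2cc1N1CCCN(C)CC1` is the next member: 4-methyl-1,4-diazepan-1-yl in place of 4-isopropylpiperazin-1-yl on an aromatic carbon. For the measured compounds named here, only the one step from compound 1 to compound 2 bears on this change, and it touched just the substituent on the amine nitrogen, not the ring size. That step was flat, so for compound 3 the expected step of a 1.1-fold higher number from compound 2 to compound 3 (0.03 log units; within the scatter) is also no change beyond the scatter. The estimate for compound 3 in this assay is 0.07, with a range from 0.035 to 0.14.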

Compound 3, unbound fraction: 0.103
Estimate against measurement, compound 3: 1.5-fold (0.17 log units) below; low and high end bracket the measured number.
By their numbers in this assay, from the lowest: compounds 1, 2 and 3 (each within the scatter of the next).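

The earlier pair varied only the group on the amine nitrogen, whereas compound 3 changes the ring itself, and in this assay the seven-membered ring stays within the scatter of both six-membered rings: a 1.6-fold higher number from compound 2 to compound 3 (0.19 log units; within the scatter), and a 1.6-fold higher number from compound 1 to compound 3 (0.21 log units; within the scatter). The comparison with compound 1 is the cleaner one, as 4-methyl-1,4-diazepan-1-yl and 4-methylpiperazin-1-yl carry the same methyl and differ only in ring size, so across these three compounds neither kind of change goes beyond the scatter. Nothing on hand offers an explanation for these numbers.

On these data alone, whether a five-membered pyrrolidine ring or an open dimethylaminoethyl chain in this place would also stay within the scatter remains open. So does whether an isopropyl group on the seven-membered ring would give a number close to that of compound 3.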